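The compounds below may be only part of what the source reports. "The series", "measured", "known", "first", "only" and "open" are said of these compounds alone.

Measured so far in a functional assay on COLO 205 cells (Homo sapiens) for inhibition, read by sulforhodamine B assay, with a stated time of 48 h; a lower number here means a stronger inhibitor of growth, a higher number a weaker inhibitor of growth:

- compound 1 `N=C(N)c1ccc(-c2ccc(-c3cc(Cl)cc(Cl)c3)s2)s1` — 1540 nM
- compound 2 `N=C(N)c1ccc(-c2ccc(-c3ccc(Cl)cc3)o2)o1` — 1830 nM
- compound 3 `COc1cc(OC)cc(-c2ccc(-c3ccc(C(=N)N)o3)o2)c1` — 1840 nM

All three numbers sit close together. Compound 2 falls in the middle of the three in this assay; the gap to compound 3 is nil and the gap to compound 1 is within the scatter, so no ordering among them can be read from these values. Among the measured compounds shown here, each compound carries a different core and a different substitution on the terminal aromatic ring, and no pair differs in a single place, so nothing is yet known about how one substituent swap moves the number.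

Compound 4 `N=C(N)c1ccc(-c2ccc(-c3ccc(F)cc3)o2)o1` is the untested member. It departs from compound 2 by a single exchange: fluoro in place of chloro on an aromatic carbon. Halogen-for-halogen swaps of this kind, in a series where the three measured values already vary less than the scatter, give no reason to expect a large move. The expected step from compound 2 to compound 4 in this assay is a 1.3-fold higher number from compound 2 to compound 4 (0.12 log units; within the scatter), at or just beyond the edge of the scatter, leaning toward a weaker inhibitor of growth. On that basis compound 4 is estimated at 2400 nM in this assay, within a range of 1000 nM to 6000 nM.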

Compound 4, concentration for 50% growth inhibition: 1600 nM
The estimate for compound 4 lay 1.5-fold (0.18 log units) above the measured number; measured number inside the range.
By their numbers in this assay, from the lowest: compounds 1, 4, 2 and 3 (each within the scatter of the next).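

In this assay, among the compounds shown here, the exchange of chloro for fluoro on an aromatic carbon of the six-membered aromatic ring, para to a large group, gives a 1.1-fold lower number from compound 2 to compound 4 (0.06 log units; within the scatter) and is the first single-place comparison available. For the compounds shown here, the two halogens therefore cannot be told apart at this position in this assay, a point the earlier compounds could not address, since no two of them differed in one place only. No accompanying measurement bears on this result, and the number alone cannot say what lies behind it.

Still open, from the compounds shown here alone, is whether this position accepts only a halogen or whether the number would also stay within the scatter with a group of a different kind there, such as an amine, a carboxylic acid or a longer alkyl chain. Also open, going by these compounds, is whether fluoro in place of chloro reads the same way on the core of compound 1, and whether removing the halogen altogether, leaving hydrogen on that carbon, would give a number distinct from those of compound 2 and compound 4.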